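A few compounds are considered here, and "the series" means these few. Any claim that something is new, unique, unknown or untested is made for them only; others in the source may bear on it.

The assay here is a toxicity assay on HepG2 cells (Homo sapiens) for inhibition, read by CellTiter-Glo, with a stated time of 48 h; on this read-out lower numbers stand for stronger inhibition and higher numbers for weaker inhibition. Two compounds have been run in it so far. Compound 1 `CCOc1ccc2nc(C(F)(F)F)cc(OCC(=O)Nc3cc(C)cc(C)c3)c2c1` reached only the upper edge of what the test can report: in this assay compound 1 gives > 100000 nM, which is a limit rather than a number. Compound 2 `COc1ccc(NC(=O)COc2cc(C)nc3ccc(OC)cc23)cc1` stands in the same place. In this assay compound 2 gives > 100000 nM, again a limit and not a measured number. That edge is the limit of > 100000 nM in this assay, at which 2 of the 2 values shown sit, so no gradation between the two compounds is visible.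

Compound 3 `COc1ccc2nc(C)cc(OCC(=O)NC3CONC3=O)c2c1` has not been measured yet. It differs from compound 2 in one spot: a group of 6 heavy atoms (3 carbon, 1 nitrogen, 2 oxygen; one five-membered non-aromatic ring with 2 hetero atoms) in place of a group of 8 heavy atoms (7 carbon, 1 oxygen; one six-membered aromatic ring of carbon only), on an amide-type nitrogen. The leaving group is a 4-methoxyphenyl; the entering group is a five-membered non-aromatic ring with 2 hetero atoms and 1 double bond outside aromatic rings, carrying 1 hydrogen-bond donor and 2 hydrogen-bond acceptors, placed on the amide-type nitrogen whose other neighbour is a carbonyl carbon.

For the measured compounds named here, because compound 2 gives > 100000 nM, only a limit, no step within the measured set can be computed, and a limit gives no foothold for a direction. The expectation for the step that the limit leaves unreadable from compound 2 to compound 3 is therefore none beyond the scatter. Compound 3 is expected to give 150000 nM, within a range from 50000 nM to 500000 nM, most likely again as a limit.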

Compound 3, half-maximal inhibitory concentration: > 100000 nM
Compound 3 gave a limit, no number; the forecaster's own chance of this, stated with the estimate: 85%; the middle value does not contradict the limit.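

In this assay compound 3 gives > 100000 nM as a limit and not a number. For the compounds shown here, compound 2 also gives only a limit, so no step between compound 2 and compound 3 can be read: the limit of > 100000 nM in this assay, at which 3 of the 3 values shown sit. The compounds shown leave open whether any of them inhibits these cells at a measurable level, and how much the change of amide group alters the read-out.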